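A few compounds are considered here, and "the series" means these few. Any claim that something is new, unique, unknown or untested is made for them only; others in the source may bear on it.

Among the three compounds measured so far, compound 3 `Cc1cncc(N2CC[C@@H]3CN[C@@H]3C2)c1` gives the lowest number: in a functional assay on HEK293 cells for agonist activity at Neuronal acetylcholine receptor; alpha4/beta2 (Homo sapiens), read by FLIPR (on this read-out higher numbers stand for an effect only at larger amounts of compound and lower numbers for an effect already at smaller amounts), compound 3 gives 650 nM. Compound 1 `Brc1cncc(N2CC[C@@H]3CN[C@@H]3C2)c1` gives 1000 nM in this assay, and the two lie within the scatter of each other, so no order between them can be claimed. Compound 2 `N#Cc1cncc(N2CC[C@@H]3CN[C@@H]3C2)c1` gives 1900 nM in this assay, and the step of a 2.9-fold lower number from compound 2 to compound 3 (0.47 log units; beyond the scatter) is the one difference among the three that lies beyond the scatter.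

Compound 4 `N/C(=N/O)c1cncc(N2CC[C@@H]3CN[C@@H]3C2)c1` differs from compound 3 by a group of 4 heavy atoms (1 carbon, 2 nitrogen, 1 oxygen; no ring) in place of one carbon atom, on an aromatic carbon. Within the data shown here, no measured step replaces a methyl with a group of this kind, so the bearing of the data is indirect. The steps available are a 1.5-fold lower number from compound 1 to compound 3 (0.19 log units; within the scatter), which is within the scatter, and a 2.9-fold lower number from compound 2 to compound 3 (0.47 log units; beyond the scatter), which is modest. Both point the same way: the methyl gives the lowest number, and the polar cyano the highest, with bromo between. The new group shares its carbon attachment and its nitrogen content with the cyano group and is larger still, so the expected direction is a higher number, of a size near that seen between compound 2 and compound 3, that is a 2.3-fold higher number from compound 3 to compound 4 (0.36 log units; beyond the scatter). Compound 4 is therefore estimated at 1500 nM, with a range from 500 nM to 4500 nM.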

Compound 4, half-maximal effective concentration: 180 nM
Estimate against measurement, compound 4: 8.3-fold (0.92 log units) above, outside the stated range (below it).
By their numbers in this assay, from the lowest: compound 4; then compounds 3, 1 and 2 (each within the scatter of the next, the first and the last beyond it).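

In this assay, among these compounds, the group with 4 heavy atoms on this aromatic carbon, two atoms from the ring nitrogen, is the first change to move the number clearly below those of all the earlier compounds, with a 3.6-fold lower number from compound 3 to compound 4 (0.56 log units; beyond the scatter), a 5.6-fold lower number from compound 1 to compound 4 (0.74 log units; beyond the scatter) and an 11-fold lower number from compound 2 to compound 4 (1.02 log units; beyond the scatter), the last being the largest of these steps. The earlier compounds spanned only a narrow band of numbers and could not show that this position accepts a group this large with no rise in the number; among these four compounds, the count of heavy atoms in the group does not follow the number, since compound 4 carries the largest group and gives the lowest number, while compound 2, with a cyano group, gives the highest. The data at hand offer nothing that accounts for this change.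

The compounds shown do not tell which part of the new group goes with the lower number. As far as these compounds go, it remains open whether a primary amide, a carboxylic acid, an aminomethyl group or the same group with its hydroxyl capped as a methyl ether would give a number like that of compound 4.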